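Pyridin-2-yl in Place of Trimethylpyrazolyl: Expected Clearance

The source may report more compounds than this note shows. Statements on the series, on what has been measured and on what is new or still open speak of the compounds shown alone.

Compound 2 `Cc1cc(C)c(-c2c(C)nn(C)c2C)cc1NC(=O)c1ccc(OCc2ccccn2)cc1` stands highest of the two numbers recorded so far in an ADME assay on microsomes from liver (Homo sapiens) for metabolic stability; on this read-out higher numbers stand for fast clearance and lower numbers for slow clearance; its nearest neighbour is compound 1 `Cc1cc(C)c(-c2nc3ccccc3[nH]2)cc1NC(=O)c1ccc(OCc2ccccn2)cc1`, and the step of a 4.1-fold higher number from compound 1 to compound 2 (0.61 log units; beyond the scatter) separates them. In this assay compound 1 gives 30 mL.min-1.g-1, and compound 2 gives 122 mL.min-1.g-1. Compound 3 `Cc1cc(C)c(-c2ccccn2)cc1NC(=O)c1ccc(OCc2ccccn2)cc1` is not yet measured. It differs from compound 2 in one place: pyridin-2-yl in place of 1,3,5-trimethyl-1H-pyrazol-4-yl on an aromatic carbon. For the measured compounds named here, the only measured step that bears on this position is a 4.1-fold higher number from compound 1 to compound 2 (0.61 log units; beyond the scatter), which exchanged one group for another on the same aromatic carbon and moved the number by a modest amount beyond the scatter. Neither measured compound carries pyridin-2-yl, so the direction for compound 3 is uncertain, and the two measured groups at this position only bracket a range. Compound 3 is therefore expected to fall between them, estimated at 60 mL.min-1.g-1 with a range from 20 mL.min-1.g-1 to 180 mL.min-1.g-1. This estimate implies a step of a 2.0-fold lower number from compound 2 to compound 3 (0.31 log units; beyond the scatter), expected to be modest and of uncertain direction in this assay.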

Compound 3, intrinsic clearance in microsomes: 209 mL.min-1.g-1
Estimate against measurement, compound 3: 3.5-fold (0.54 log units) below; measured number above the stated range.
By their numbers in this assay, from the lowest: compound 1; then compounds 2 and 3 (each within the scatter of the next).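

In this assay, pyridin-2-yl in place of 1,3,5-trimethyl-1H-pyrazol-4-yl gives a 1.7-fold higher number from compound 2 to compound 3 (0.23 log units; within the scatter), so on this read-out the two groups cannot be told apart, although one is a five-membered aromatic ring with 2 hetero atoms and the other a six-membered aromatic ring with 1 hetero atom. Pyridin-2-yl in place of 1H-benzimidazol-2-yl gives a 7.0-fold higher number from compound 1 to compound 3 (0.84 log units; beyond the scatter), and this shows that compound 1 stands apart at this position: of the three groups on this aromatic carbon, only 1H-benzimidazol-2-yl gives a number separated from both others beyond the scatter. Nothing at hand accounts for why compound 1 differs from compound 2 and compound 3 or why those two cannot be separated.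

On these data alone, whether the lower number of compound 1 belongs to the whole 1H-benzimidazol-2-yl group or to only a part of it remains open, and a 1H-imidazol-2-yl group on the same aromatic carbon would speak to that. As far as these compounds go, it is also open whether the same picture would hold if the pyridin-2-ylmethoxy group of the shared core gave way to a simple methoxy group.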